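Limits at the low end: a thiazole to methoxypyridine swap

A few compounds are considered here, and "the series" means these few. Any claim that something is new, unique, unknown or untested is made for them only; others in the source may bear on it.

Values in an in vitro ADME assay on microsomes from liver (Homo sapiens) for metabolic stability (on this read-out higher numbers stand for fast clearance and lower numbers for slow clearance), all three of them limits:
compound 1 `Cc1ccc(Cn2c(=O)[nH]c3c(N)nc(-c4ncco4)cc32)cn1`: < 7 mL.min-1.g-1
compound 2 `Cc1cc(Cn2c(=O)[nH]c3c(N)nc(C(F)(F)F)cc32)no1`: < 8 mL.min-1.g-1
compound 3 `Cc1nc(Cn2c(=O)[nH]c3c(N)nc(C(F)(F)F)cc32)cs1`: < 7 mL.min-1.g-1

Compound 3 has no number on this read-out and stands at the limit of < 7 mL.min-1.g-1 in this assay, at which 2 of the 3 values shown sit. Compound 2 stands at the limit of < 8 mL.min-1.g-1 in this assay, at which 1 of the 3 values shown sits. Among the measured compounds shown here, the only measured step that bears on the next change is a step that the two limits leave unreadable from compound 2 to compound 3. That step concerns the same place in the series, but it gives no size to carry forward.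

Compound 4 `COc1ccc(Cn2c(=O)[nH]c3c(N)nc(C(F)(F)F)cc32)cn1` has not yet been measured in this assay. Its difference from compound 3 is 6-methoxypyridin-3-yl in place of 2-methyl-1,3-thiazol-4-yl on a saturated chain carbon bound to an aromatic nitrogen. In words, this is 6-methoxypyridin-3-yl in place of 2-methyl-1,3-thiazol-4-yl on a saturated chain carbon bound to an aromatic nitrogen.

The expectation rests on compound 3, whose value of < 7 mL.min-1.g-1 is a limit. No step beyond the scatter is expected in this assay, and any departure is expected only towards faster clearance. The expected change is a number no lower from compound 3 to compound 4 (the limit leaves the size open). For compound 4 the estimate is 7 mL.min-1.g-1, with an expected range from 4 mL.min-1.g-1 to 14 mL.min-1.g-1.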

Compound 4, intrinsic clearance in microsomes: < 8 mL.min-1.g-1
Compound 4 gave a limit, no number; the forecaster's own chance of this, stated with the estimate: 60%; the middle value does not contradict the limit.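

In this assay compound 4 gives only a limit, < 8 mL.min-1.g-1. Compound 2 and compound 3 are also limits, so the steps from each of them to compound 4 cannot be read. The compounds shown leave open whether 6-methoxypyridin-3-yl, 2-methyl-1,3-thiazol-4-yl and 5-methyl-1,2-oxazol-3-yl differ at all in clearance.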